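This account rests on a few compounds, and the source may have more. Where it says the series, first, only, none or still open, it means among the compounds named here.

Compound 1 `Clc1ccc(Cc2nn3cc(-c4ccc(Cl)cc4Cl)nc3s2)cc1` and compound 2 `Clc1ccc(Cc2nn3cc(-c4ccccc4)nc3s2)cc1` share a core; compound 3 `N#CSc1c(-c2ccc(Cl)cc2Cl)nc2sc(Cc3ccc(Cl)cc3)nn12` carries a cyanosulfanyl on the core of compound 1, and compound 4 `N#CSc1c(-c2ccccc2)nc2sc(Cc3ccc(Cl)cc3)nn12` is not yet measured. In an ADME assay on CCRF-CEM cells (Homo sapiens) for cytotoxicity, with a stated time of 72 h (a higher number here means a weaker inhibitor, a lower number a stronger inhibitor), compound 1 gives > 250000 nM, a limit of the assay. Compound 2 gives > 250000 nM, likewise a limit. Compound 3 gives 46000 nM. The step of an at least 5.4-fold lower number from compound 1 to compound 3 (0.73 log units; beyond the scatter) goes with the change (cyanosulfanyl in place of hydrogen on an aromatic carbon). The change phenyl in place of 2,4-dichlorophenyl on an aromatic carbon gives a step that the two limits leave unreadable from compound 1 to compound 2 because both values sit at the limit of > 250000 nM in this assay, at which 2 of the 3 values shown sit. The same kind of change, (phenyl in place of 2,4-dichlorophenyl on an aromatic carbon), is made on the core of compound 3; its place differs in being next to the ring atom that bears a cyanosulfanyl group (3 heavy atoms). With the step from compound 1 to compound 2 unreadable, compound 4 is expected to show a 1.7-fold higher number from compound 3 to compound 4 (0.24 log units; within the scatter) in this assay, with a fair chance of a limit. Compound 4 is estimated at 80000 nM, between 30000 nM and 250000 nM.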

Compound 4, half-maximal inhibitory concentration: 14000 nM
For compound 4 the middle estimate is 5.7-fold (0.76 log units) above the measured one; measured number outside the range, below it.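

In this assay cyanosulfanyl in place of hydrogen on an aromatic carbon gives an at least 17-fold lower number from compound 2 to compound 4 (1.25 log units; beyond the scatter) and the direction is the same on both cores, but the sizes cannot be compared: the same change on two cores in this assay, an at least 5.4-fold lower number (0.73 log units; beyond the scatter) from compound 1 to compound 3 and an at least 17-fold lower number (1.25 log units; beyond the scatter) from compound 2 to compound 4; the limit leaves it open whether they differ.
Phenyl in place of 2,4-dichlorophenyl gives a 3.3-fold lower number from compound 3 to compound 4 (0.52 log units; beyond the scatter) with cyanosulfanyl present, while the same change without that group cannot be read: the limit of > 250000 nM in this assay, at which 2 of the 4 values shown sit.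
The cyanosulfanyl step therefore carries over in direction across these two cores only, and nothing shows whether the phenyl step carries over.

The compounds shown leave open whether a methylsulfanyl or an amine in place of cyanosulfanyl would also lower the number. They also leave open whether a single chlorine on the phenyl would behave like 2,4-dichlorophenyl or like phenyl.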